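Nitrophenyl in place of fluorophenyl: expectation for compound 3

This account rests on a few compounds, and the source may have more. Where it says the series, first, only, none or still open, it means among the compounds named here.

Compound 1 `O=C(/C=C/c1cccc(F)c1)NCCCCNc1ccnc2cc(Cl)ccc12` and compound 2 `O=C(/C=C/c1ccc(F)cc1)NCCCCNc1ccnc2cc(Cl)ccc12` share one core and differ only in the aryl group on the double-bonded chain carbon. In a functional assay on MCF7 cells (Homo sapiens) for antiproliferative activity, read by sulforhodamine B assay, with a stated time of 2 days (a higher number here means a weaker inhibitor of growth, a lower number a stronger inhibitor of growth), compound 1 gives 14900 nM. In this assay compound 2 gives 12500 nM, the lower of the two numbers, though a 1.2-fold lower number from compound 1 to compound 2 (0.08 log units; within the scatter) places it within the scatter of compound 1. Compound 3 `O=C(/C=C/c1ccccc1[N+](=O)[O-])NCCCCNc1ccnc2cc(Cl)ccc12` is the next member: 2-nitrophenyl in place of 4-fluorophenyl on a double-bonded chain carbon bound to a double-bonded chain carbon. Among the measured compounds shown here, the only step measured so far alters the same aryl group, and a 1.2-fold lower number from compound 1 to compound 2 (0.08 log units; within the scatter) shows that exchanging one fluorophenyl for another left the number essentially unchanged. For the measured compounds named here, no measured step involves a nitrophenyl, so nothing in these two compounds argues for a direction. The expectation is therefore a step of a 1.0-fold higher number from compound 2 to compound 3 (0.02 log units; within the scatter), not beyond the scatter. Compound 3 is estimated at 13000 nM in this assay, with a range from 5000 nM to 35000 nM.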

Compound 3, concentration for 50% growth inhibition: 13300 nM
For compound 3 the middle estimate is 1.0-fold (0.01 log units) below the measured one, within the range that was stated.
By their numbers in this assay, from the lowest: compounds 2, 3 and 1 (each within the scatter of the next).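

In this assay, the step of a 1.1-fold higher number from compound 2 to compound 3 (0.03 log units; within the scatter) and the step of a 1.1-fold lower number from compound 1 to compound 3 (0.05 log units; within the scatter) both stay within the scatter, so all three aryl groups on the double-bonded chain carbon give numbers that cannot be told apart. Until now this position had been compared only between two fluorophenyl groups; 2-nitrophenyl is a larger group with hydrogen-bond acceptors, which the fluorophenyl groups lack, and these differences bring no step beyond the scatter here. No supporting measurement is available to explain this result.

Going by these compounds, whether any aryl group at this position can produce a step beyond the scatter remains open, for example a phenyl carrying an amine or a carboxylic acid. The compounds shown also leave open how a longer chain linking the amide to the shared core would read in this assay.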